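A Five-Membered Ring Exchange Across Two Related Cores

This account rests on a few compounds, and the source may have more. Where it says the series, first, only, none or still open, it means among the compounds named here.

Compound 1 `Cc1noc(C)c1-c1cnc(N)c(Oc2ccc(C(=O)Nc3ccc(Cl)cn3)cc2)n1` and compound 2 `Cn1cc(-c2cnc(N)c(Oc3ccc(C(=O)Nc4ccc(Cl)cn4)cc3)n2)cn1` share one core; in a functional assay on HeLa cells (Homo sapiens) for inhibition, read by MTT assay, with a stated time of 72 h (on this read-out higher numbers stand for weaker inhibition and lower numbers for stronger inhibition), compound 1 gives 19200 nM and compound 2 gives 21500 nM. The change between them is 1-methyl-1H-pyrazol-4-yl in place of 3,5-dimethyl-1,2-oxazol-4-yl on an aromatic carbon and it produced a 1.1-fold higher number from compound 1 to compound 2 (0.05 log units; within the scatter). Compound 3 `Cc1noc(C)c1-c1cnc(N)c(NCc2ccc(C(=O)Nc3ccc(Cl)cc3)cc2)n1` stands on a second core, and the difference between the two cores is not broken down here. In this assay compound 3 reaches only a limit of the assay, > 100000 nM, namely (the limit of > 100000 nM in this assay, at which 1 of the 3 values shown sits). Compound 4 `Cn1cc(-c2cnc(N)c(NCc3ccc(C(=O)Nc4ccc(Cl)cc4)cc3)n2)cn1` carries the same change on this second core, (1-methyl-1H-pyrazol-4-yl in place of 3,5-dimethyl-1,2-oxazol-4-yl on an aromatic carbon). For compound 4 the step that the limit leaves unreadable from compound 3 to compound 4 is expected to stay within the scatter, because a 1.1-fold higher number from compound 1 to compound 2 (0.05 log units; within the scatter) showed the same change to be near-neutral on the first core. Compound 4 is therefore estimated at 150000 nM, between 50000 nM and 500000 nM, most likely again reported only as a limit.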

Compound 4, half-maximal inhibitory concentration: 42100 nM
Estimate against measurement, compound 4: 3.6-fold (0.55 log units) above; the measured number lies below the stated range.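

In this assay, from the compounds shown here alone, the exchange gives an at least 2.3-fold lower number from compound 3 to compound 4 (0.37 log units; beyond the scatter) on the second core, a step beyond the scatter whose full size stays unknown. The value of compound 3 is a limit of the assay: the limit of > 100000 nM in this assay, at which 1 of the 4 values shown sits. The two steps can be called neither equal nor different, and two cores are too few to set a rule for the series: the same change on two cores in this assay, a 1.1-fold higher number (0.05 log units; within the scatter) from compound 1 to compound 2 and an at least 2.3-fold lower number (0.37 log units; beyond the scatter) from compound 3 to compound 4; the limit leaves it open whether they differ.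

Going by these compounds, what a pyridine ring or a morpholine in place of either five-membered ring would give remains open. Also open, on these data alone, is how the same exchange would read on a further core, for example one carrying a carboxylic acid in place of the chlorine.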